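A few compounds are considered here, and "the series" means these few. Any claim that something is new, unique, unknown or untested is made for them only; others in the source may bear on it.

The four compounds here are built on closely related cores that carry a ring amine, either bearing a small substituent or left as a free amine. Compound 2 `N=C(N)N1CC23CCCC2(CCC3)C1` gives 54000 nM in an ADME assay on MDCK cells (Canis lupus familiaris) for cytotoxicity, read by microscopy; on this read-out higher numbers stand for lower toxicity in this test and lower numbers for higher toxicity in this test. Compound 1 `C1CC23CCCC2(C1)CNC3` reaches only the limit of > 100000 nM in this assay. The change a hydrogen atom in place of a group of 3 heavy atoms (1 carbon, 2 nitrogen; no ring), on an amine nitrogen in a ring therefore produced an at least 1.8-fold higher number from compound 2 to compound 1 (0.26 log units; that floor lies within the scatter). Compound 3 `CC1CC23CC(C)CC2(C1)CN(C(=N)N)C3` likewise reaches only the limit of > 100000 nM in this assay. The difference between the core of compound 3 and that of compound 2 is not broken down here. Compound 4 `CC1CC23CNCC2(C1)CC(C)C3` is not yet measured and differs from compound 3 by the same change, (a hydrogen atom in place of a group of 3 heavy atoms (1 carbon, 2 nitrogen; no ring), on an amine nitrogen in a ring). Because the limit of > 100000 nM in this assay, at which 2 of the 3 values shown sit, already holds compound 3, and the earlier change gave an at least 1.8-fold higher number from compound 2 to compound 1 (0.26 log units; that floor lies within the scatter), the step is expected to be a step that the limit leaves unreadable from compound 3 to compound 4. Compound 4 is estimated at 150000 nM, between 60000 nM and 400000 nM.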

Compound 4, minimum cytotoxic concentration: > 100000 nM
Compound 4: a limit, no number; the forecaster's own chance of this, stated with the estimate: 85%; the middle value lies beyond the limit too.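

In this assay compound 3 and compound 4 both stand only as limits, and no step can be read between them. The compounds shown leave open whether this change has any effect on the core of compound 3.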